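A few compounds are considered here, and "the series" means these few. Any claim that something is new, unique, unknown or untested is made for them only; others in the source may bear on it.

Compound 2 `O=C(C1CCCN(Cc2ccc(Br)cc2)C1)N1CCN(c2ccccc2Cl)CC1` stands second highest of the three numbers in a functional assay on a cell-free system (Platelet, plasma, Homo sapiens), with stated times of 4 min and 5.5 min, tested at 1 uM (on this read-out higher numbers stand for a weaker effect at the one concentration tested and lower numbers for a stronger effect), where compound 2 gives 39%. Compound 1 `O=C(C1CCCN(Cc2ccc(F)cc2)C1)N1CCN(c2ccccc2Cl)CC1` gives 40%, and compound 3 `O=C(C1CCCN(Cc2ccc([N+](=O)[O-])cc2)C1)N1CCN(c2ccccc2Cl)CC1` gives 23%. The step of a number 1 percentage points lower from compound 1 to compound 2 (within the scatter) lies within the scatter, whereas a number 16 percentage points lower from compound 2 to compound 3 (beyond the scatter) and a number 17 percentage points lower from compound 1 to compound 3 (beyond the scatter) lie beyond it. Compound 4 `O=C(C1CCCN(Cc2ccc(Br)cc2)C1)N1CCN(c2ccccn2)CC1` differs from compound 2 by pyridin-2-yl in place of 2-chlorophenyl on an amine nitrogen in a ring. Among the compounds with values here, no measured step touches this part of the shared core; all three exchange one substituent for another on an aromatic carbon of a different ring, so none of them bears on this change. Compound 4 is therefore expected to show a step of a number 6 percentage points higher from compound 2 to compound 4 (within the scatter) that is small and uncertain. The estimate for compound 4 is 45%, within the range 25% to 70%.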

Compound 4, a percentage reported as activity, at one concentration (the size of the read-out at that concentration, not a potency): 24%
Beside the measured number, compound 4's estimate is 21 percentage points above it; measured number outside the range, below it.
By their numbers in this assay, from the lowest: compounds 3 and 4 (each within the scatter of the next); then compounds 2 and 1 (each within the scatter of the next).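

In this assay, pyridin-2-yl in place of 2-chlorophenyl gives a number 15 percentage points lower from compound 2 to compound 4 (beyond the scatter). Within the data shown here, this shows that the group on the amine nitrogen in a ring can shift the read-out beyond the scatter, which the earlier steps, all made on the other aromatic ring, could not show. Nothing available here explains this step. As far as these compounds go, it remains open whether an unsubstituted phenyl or a pyrimidinyl group on this nitrogen would give a similar number. From the compounds shown here alone, it also remains open whether the same exchange would have a similar effect with fluoro or nitro in place of bromo.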